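Propyl Replaces 3-Methylphenyl on the Amide Nitrogen

The source may hold more compounds than are shown below. What is called first, only, known or untested is meant among the compounds shown, and "the series" means these compounds.

Three compounds sharing one core have been examined in a functional assay on HeLa cells (Homo sapiens) for cytotoxicity, read by MTT assay, with a stated time of 24 h; a lower number here means a stronger inhibitor, a higher number a weaker inhibitor. Compound 1 `C=CC1=C(C(=O)Nc2ccccc2)C(c2ccc(Cl)c(Cl)c2)OC1` was reported only as a limit of the assay, > 100000 nM. Compound 2 `C=CC1=C(C(=O)NC2CCCCC2)C(c2ccc(OC)cc2)OC1` gave 24800 nM in this assay. Compound 3 `C=CC1=C(C(=O)Nc2cccc(C)c2)C(c2ccc(F)cc2)OC1` was recorded in this assay as "not active" (no number reported), with no number attached; it thus stands with compound 1 rather than compound 2, and where compound 1 sits is shown by the limit of > 100000 nM in this assay, at which 1 of the 3 values shown sits.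

The untested compound 4 `C=CC1=C(C(=O)NCCC)C(c2ccc(F)cc2)OC1` differs from compound 3 in one place: propyl in place of 3-methylphenyl on an amide-type nitrogen. The aromatic part on the other side of the core is kept. Compound 3 carries only a "not active" report and compound 1 only a limit of the assay. Among the compounds with values here, the step from compound 3 to compound 4 in this assay is expected to be small or to end in the same weak region, since compound 2, the one compound with a number, still sits at 24800 nM. Compound 4 is therefore estimated to give 80000 nM, with a likely range from 20000 nM to 300000 nM.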

Compound 4, half-maximal inhibitory concentration: > 100000 nM
Compound 4: only a limit was reported; the forecaster's own chance of this, stated with the estimate: 60%; at least 1.2-fold (0.09 log units) between middle value and limit.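

No step can be read from compound 3 to compound 4: compound 3 has only a "not active" report, and compound 4 has only a limit of the assay, > 100000 nM. The compounds shown leave open whether exchanging 3-methylphenyl for propyl changes potency in this assay.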